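Amino substituent exchange on the shared core

The source may report more compounds than this note shows. Statements on the series, on what has been measured and on what is new or still open speak of the compounds shown alone.

Compound 3 `COCC(COC)Nc1nc(C)nc2c1nnn2-c1ccc(C(C)C)cc1Br` gives 10.3 nM in an in vitro assay on 293-EBNA cells for binding affinity to corticotropin-releasing factor receptor 1 (Homo sapiens) (a lower number here means a stronger inhibitor, a higher number a weaker inhibitor), the lowest of the three numbers recorded so far. Compound 1 `CCC(COC)N(C)c1nc(C)nc2c1nnn2-c1ccc(C(C)C)cc1Br` gives 11.2 nM, and the step of a 1.1-fold lower number from compound 1 to compound 3 (0.04 log units; within the scatter) sits within the scatter. Compound 2 `CCCCN(CC)c1nc(C)nc2c1nnn2-c1c(C)cc(C)cc1C` gives 27.5 nM, a number beyond the scatter from compound 3. Compound 4 `CCCCN(CC)c1nc(C)nc2c1nnn2-c1ccc(C(C)C)cc1Br` carries butyl(ethyl)amino in place of (2-methoxy-1-(methoxymethyl)ethyl)amino on an aromatic carbon. For the measured compounds named here, no measured step covers this exact exchange. What bears on it is that compound 1 and compound 3 differ at the same place with a 1.1-fold lower number from compound 1 to compound 3 (0.04 log units; within the scatter), and that compound 2 carries the same butyl(ethyl)amino group, differs elsewhere, and gives 27.5 nM. A small step at most is therefore expected, a 1.5-fold higher number from compound 3 to compound 4 (0.16 log units; within the scatter). Compound 4 is estimated at 15 nM, with a range of 5 nM to 45 nM.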

Compound 4, inhibition constant: 7.5 nM
Compound 4: the middle estimate sits 2.0-fold (0.30 log units) above what was measured; low and high end bracket the measured number.
By their numbers in this assay, from the lowest: compounds 4, 3 and 1 (each within the scatter of the next); then compound 2.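

At this aromatic carbon in this assay, butyl(ethyl)amino, with 0 hydrogen-bond donors and 1 hydrogen-bond acceptor, stands level with (2-methoxy-1-(methoxymethyl)ethyl)amino (a 1.4-fold lower number from compound 3 to compound 4 (0.14 log units; within the scatter)). The group of 8 heavy atoms with 1 oxygen reads the same way against butyl(ethyl)amino (a 1.5-fold lower number from compound 1 to compound 4 (0.17 log units; within the scatter)). Oxygen in the chain and the amine hydrogen are therefore not required for a number of this size on the shared core. No data at hand account for this flat response. Open, on these data alone, is whether a morpholine ring or a carboxylic acid at this carbon would stay in the same range.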